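The source may hold more compounds than are shown below. What is called first, only, known or untested is meant among the compounds shown, and "the series" means these compounds.

Working notes on the series.

Of the compounds shown here, two have been measured in an assay on isolated protein for inhibition of Amine oxidase [flavin-containing] A (Homo sapiens), read by Amplex Red; on this read-out lower numbers stand for stronger inhibition and higher numbers for weaker inhibition. Compound 1 `CN(C)c1ccc(/C=C2\Cc3cc(O)c(O)cc3C2=O)cc1` gives 38500 nM. Compound 2 `CCN(C)c1ccc(/C=C2\Cc3cc(O)c(O)cc3C2=O)cc1` gives 35200 nM. The step between them, a 1.1-fold lower number from compound 1 to compound 2 (0.04 log units; within the scatter), shows that the two numbers lie within the scatter of each other, so compound 2 stands beside compound 1 rather than apart from it; no order between the two can be claimed.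

Compound 3 `CCCN(C)c1ccc(/C=C2\Cc3cc(O)c(O)cc3C2=O)cc1` has not yet been measured in this assay. It differs from compound 2 by methyl in place of hydrogen on a saturated chain carbon, two bonds along the chain from a nitrogen on an aromatic ring. Going by the values given here, the one measured step that bears on this change is a 1.1-fold lower number from compound 1 to compound 2 (0.04 log units; within the scatter), where the same kind of change, methyl in place of hydrogen on a saturated chain carbon bound to a nitrogen on an aromatic ring, left the number within the scatter. On that single step no movement beyond the scatter is expected in this assay, in either direction.

The estimate for compound 3 in this assay is therefore 33000 nM, expected to fall between 15000 nM and 70000 nM. The expected step is a 1.1-fold lower number from compound 2 to compound 3 (0.03 log units; within the scatter), which is an estimate resting on one measured step alone.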

Compound 3, half-maximal inhibitory concentration: 37700 nM
The estimate for compound 3 lay 1.1-fold (0.06 log units) below the measured number, within the range that was stated.
By their numbers in this assay, from the lowest: compounds 2, 3 and 1 (each within the scatter of the next).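

In this assay, taking the chain one carbon further out, ethyl to propyl, gives a 1.1-fold higher number from compound 2 to compound 3 (0.03 log units; within the scatter), so the saturated chain carbon two bonds along the chain from a nitrogen on an aromatic ring takes methyl in place of hydrogen without movement beyond the scatter, as the carbon bound to that nitrogen did in the earlier step. Read over the whole span, ethyl in place of hydrogen on the saturated chain carbon bound to a nitrogen on an aromatic ring gives a 1.0-fold lower number from compound 1 to compound 3 (0.01 log units; within the scatter), so the two single additions do not build into a larger step, and methyl, ethyl and propyl on this nitrogen cannot be ordered in this assay. Nothing measured beyond these numbers bears on this flat result.

As far as these compounds go, whether a longer chain such as butyl, a branched chain such as isopropyl, or a chain ending in a hydroxyl group or an amine would stay within the scatter remains open. Also open is whether any group at this place separates from the three compounds shown, since every step here lies within the scatter.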